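Nitro for Methoxy on a Chalcone Arm

The source may hold more compounds than are shown below. What is called first, only, known or untested is meant among the compounds shown, and "the series" means these compounds.

Two compounds from this study share a chromene-bearing core and differ in the ring at the far end of the enone. Compound 1 `COc1cccc(/C=C/C(=O)c2ccc(OC)c3c2OC(C)(C)C=C3)c1` carries a 3-methoxyphenyl there; in a functional assay on SW-620 cells (Homo sapiens) for antiproliferative activity, read by MTT assay, with a stated time of 24 h (on this read-out higher numbers stand for weaker inhibition and lower numbers for stronger inhibition), compound 1 gives only a limit, > 10000 nM, and sits at the limit of > 10000 nM in this assay, at which 1 of the 2 values shown sits, rather than at a measured number. Compound 2 `COc1ccc(C(=O)/C=C/c2ccc3ccccc3n2)c2c1C=CC(C)(C)O2` carries a quinoline in that position and gives 2250 nM in this assay. For the measured compounds named here, no step between two measured compounds is available here, so the size of a single change is not yet known. Compound 3 `COc1ccc(C(=O)/C=C/c2cccc([N+](=O)[O-])c2)c2c1C=CC(C)(C)O2` is compound 1 with nitro in place of methoxy on an aromatic carbon. The step from compound 1 to compound 3 is expected to be an at least 1.4-fold lower number from compound 1 to compound 3 (0.15 log units; that floor lies within the scatter), a modest gain at best. Compound 3 is therefore estimated at 7000 nM, within a range from 2000 nM to 25000 nM.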

Compound 3, half-maximal inhibitory concentration: 4090 nM
For compound 3 the middle estimate is 1.7-fold (0.23 log units) above the measured one; the measured number falls inside the stated range.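

At the far ring of the chalcone arm, where 3-methoxyphenyl becomes 3-nitrophenyl, there is now a first single-place step: in this assay this change gives an at least 2.4-fold lower number from compound 1 to compound 3 (0.38 log units; beyond the scatter). Swapping this one group is thus enough to turn a limit into a measured number, something the earlier pair could not show, as those two compounds differ by a whole ring at that end. The full size of the gain stays unknown, and the step is only a floor, because compound 1 has a limit rather than a measured value: the limit of > 10000 nM in this assay, at which 1 of the 3 values shown sits.

The compounds shown leave open whether other groups on that same aromatic carbon, such as an amine or a carboxylic acid, would lower the number further or raise it. They also leave open whether nitro would give a similar step in another position on that ring.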